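From 4-chlorobenzyl to 1-phenylcyclopropyl on a sulfonyl sulfur

The source may report more compounds than this note shows. Statements on the series, on what has been measured and on what is new or still open speak of the compounds shown alone.

Compound 1 `N#Cc1cc2c(nc1N1CCC(C(=O)NS(=O)(=O)Cc3cc(Cl)cc(Cl)c3)CC1)COC2=O`: 30500 nM
Compound 2 `N#Cc1cc2c(nc1N1CCC(C(=O)NS(=O)(=O)c3ccc(Cl)s3)CC1)COC2=O`: 4470 nM
Compound 3 `N#Cc1cc2c(nc1N1CCC(C(=O)NS(=O)(=O)Cc3ccc(Cl)cc3)CC1)COC2=O`: 4420 nM

Compound 3 stands at the low end of a functional assay (Platelet, plasma) for inhibition, with Homo sapiens as the target (a higher number here means a weaker inhibitor, a lower number a stronger inhibitor), but holds no real lead, since the measured step is a 1.0-fold lower number from compound 2 to compound 3 (0.00 log units; within the scatter). The gap on the other side is larger, at a 6.9-fold lower number from compound 1 to compound 3 (0.84 log units; beyond the scatter).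

Compound 4 `N#Cc1cc2c(nc1N1CCC(C(=O)NS(=O)(=O)C3(c4ccccc4)CC3)CC1)COC2=O` carries 1-phenylcyclopropyl in place of 4-chlorobenzyl on a sulfonyl sulfur.

For the measured compounds named here, three measured steps bear on this change, all of them swaps of the same group. Two are modest, a 6.9-fold lower number from compound 1 to compound 3 (0.84 log units; beyond the scatter) and a 6.8-fold lower number from compound 1 to compound 2 (0.83 log units; beyond the scatter), and the third, a 1.0-fold lower number from compound 2 to compound 3 (0.00 log units; within the scatter), stays within the scatter. Going by the values given here, none of the measured compounds has a cyclopropyl ring or lacks chlorine, so the data offer no direct test of either feature. The direction is therefore uncertain, and a modest step is the largest that these precedents suggest. The expected change is a 1.6-fold higher number from compound 3 to compound 4 (0.20 log units; within the scatter), a small rise that may not clear the scatter. For compound 4 the estimated value in this assay is 7000 nM, with an expected range of 2000 nM to 25000 nM.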

Compound 4, half-maximal inhibitory concentration: 4100 nM
The estimate for compound 4 lay 1.7-fold (0.23 log units) above the measured number, and the stated range covers the measured number.
By their numbers in this assay, from the lowest: compounds 4, 3 and 2 (each within the scatter of the next); then compound 1.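

In this assay the 1-phenylcyclopropyl group on the sulfonyl sulfur stands level with 4-chlorobenzyl, with a 1.1-fold lower number from compound 3 to compound 4 (0.03 log units; within the scatter), and with 5-chlorothiophen-2-yl, with a 1.1-fold lower number from compound 2 to compound 4 (0.04 log units; within the scatter), so this position holds a three-membered ring and a group without chlorine with no readable change. Only 3,5-dichlorobenzyl stays apart, with a 7.4-fold lower number from compound 1 to compound 4 (0.87 log units; beyond the scatter), which shows that chlorine is not needed to reach the level shared by compound 2, compound 3 and compound 4, while compound 1 carries chlorine and still gives the highest number. Nothing available explains why these groups match or why 3,5-dichlorobenzyl differs.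

The compounds shown leave open whether the cyclopropyl ring itself contributes, since plain benzyl does not appear among them. They also leave open how an amine or a carboxylic acid on the phenyl ring of compound 4 would read in this assay.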